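Replacing Chloro with Methoxy in Compound 3

This account rests on a few compounds, and the source may have more. Where it says the series, first, only, none or still open, it means among the compounds named here.

In a functional assay, read by spectrophotometry (a lower number here means a stronger inhibitor, a higher number a weaker inhibitor), compound 1 `CCOC(=O)N1CCC(=NNC(=O)c2ccc([N+](=O)[O-])cc2[N+](=O)[O-])CC1` gives 117000 nM, compound 2 `O=C(NN=C1CC(c2ccccc2)NC(c2ccccc2)C1)c1ccccc1` gives 238000 nM and compound 3 `O=C(NN=C1CC(c2ccccc2)NC(c2ccccc2)C1)c1ccc(Cl)cc1` gives 67900 nM. Compound 3 therefore stands within the scatter of compound 1 and is a clearly stronger inhibitor than compound 2.

The next compound, compound 4 `COc1ccc(C(=O)NN=C2CC(c3ccccc3)NC(c3ccccc3)C2)cc1`, keeps the core of compound 3 but has methoxy in place of chloro on an aromatic carbon. Among the compounds with values here, no measured compound carries methoxy, so only one measured step offers guidance. That step, a 3.5-fold lower number from compound 2 to compound 3 (0.54 log units; beyond the scatter), is modest and replaces hydrogen with chloro on an aromatic carbon. Methoxy is expected to give back only part of that step in this assay. The estimated change is a 1.8-fold higher number from compound 3 to compound 4 (0.25 log units; within the scatter), a small rise in the number that is not expected to lie beyond the scatter. Compound 4 is estimated at 120000 nM, with an expected range of 50000 nM to 280000 nM.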

Compound 4, half-maximal inhibitory concentration: 27900 nM
Beside the measured number, compound 4's estimate is 4.3-fold (0.63 log units) above it, outside the stated range (below it).
By their numbers in this assay, from the lowest: compound 4; then compounds 3 and 1 (each within the scatter of the next); then compound 2.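

In this assay, methoxy at this position, on an aromatic carbon para to a large group, goes further than chloro, with a 2.4-fold lower number from compound 3 to compound 4 (0.39 log units; beyond the scatter) beyond the scatter. Set against the unsubstituted compound, the same group gives an 8.5-fold lower number from compound 2 to compound 4 (0.93 log units; beyond the scatter), so the lower number seen with chloro is not particular to chloro among the groups shown here. Nothing available here explains why methoxy gives the lower number of the two.

Going by these compounds, with only hydrogen, chloro and methoxy compared at this position, it remains open whether an amine, a carboxylic acid or a longer chain such as ethoxy would lower the number further or raise it. On these data alone, it is also open whether methoxy would give a similar step at another place on this ring or on a different core.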